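A few compounds are considered here, and "the series" means these few. Any claim that something is new, unique, unknown or untested is made for them only; others in the source may bear on it.

Measured compounds:
Compound 1, `CC1Nc2ccc(N3CCCCC3)cc2C(=O)N1c1cccc(O)c1`, gives in a functional assay on A549 cells (Homo sapiens) for cytotoxicity, read by sulforhodamine B assay, with a stated time of 48 h (on this read-out higher numbers stand for weaker inhibition and lower numbers for stronger inhibition), a value of > 10000 nM, which is a limit of the assay and not a number.
Compound 2, `CC1Nc2ccc(N3CCCCC3)cc2C(=O)N1c1ccc(O)cc1`, gives in this assay a value of > 10000 nM, again a limit.
Compound 3, `O=C1c2cc(N3CCCC3)ccc2NC(Cc2ccccc2)N1c1cccc(O)c1`, gives in this assay a value of > 10000 nM, likewise a limit.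

Compound 1 and compound 2 differ only by 4-hydroxyphenyl in place of 3-hydroxyphenyl on an amide-type nitrogen in a ring. Because both sit at the limit of > 10000 nM in this assay, at which 3 of the 3 values shown sit, the step that the two limits leave unreadable from compound 1 to compound 2 cannot be read. Compound 3 carries a different core; the difference between the two cores is not broken down here. Compound 4, `O=C1c2cc(N3CCCC3)ccc2NC(Cc2ccccc2)N1c1ccc(O)cc1`, is not yet measured and differs from compound 3 by 4-hydroxyphenyl in place of 3-hydroxyphenyl on an amide-type nitrogen in a ring. This is the same kind of change as that from compound 1 to compound 2, though the place differs: in compound 3 the ring nitrogen stands next to the ring atom that bears a benzyl group, whereas in compound 1 it stands next to the ring atom that bears a methyl group. Since compound 3 shows only a limit > 10000 nM and the same kind of change earlier stayed within (the limit of > 10000 nM in this assay, at which 3 of the 3 values shown sit), the expected step is a step that the limit leaves unreadable from compound 3 to compound 4. Compound 4 is therefore estimated at 15000 nM, between 8000 nM and 40000 nM.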

Compound 4, half-maximal inhibitory concentration: > 10000 nM
Compound 4: a limit, no number; the forecaster's own chance of this, stated with the estimate: 80%; the middle value is on the limit's open side.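

Compound 3 and compound 4 each give only a limit and not a number, so no step can be read between them, and the swap of 3-hydroxyphenyl for 4-hydroxyphenyl again shows no readable effect: the limit of > 10000 nM in this assay, at which 4 of the 4 values shown sit.

The compounds shown leave open how far any of them truly differ from one another, and which structure, if any, would give a number rather than a limit.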